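Swapping phenyl for isopentyl on the amine nitrogen

A few compounds are considered here, and "the series" means these few. Any claim that something is new, unique, unknown or untested is made for them only; others in the source may bear on it.

Compound 1 `CC(=O)NC[C@H]1CN(c2ccc(OC[C@H](O)CNc3ccccc3)c(F)c2)C(=O)O1` gives 0.59 in a physicochemical assay for lipophilicity, read by HPLC (a higher number here means a more lipophilic compound, a lower number a more polar compound), the lowest of the two numbers measured; its nearest neighbour is compound 2 `CC(=O)NC[C@H]1CN(c2ccc(OC[C@@H](O)CNCCC(C)C)c(F)c2)C(=O)O1`, which gives 1.17. Compound 3 `CC(=O)NC[C@H]1CN(c2ccc(OC[C@H](O)CNCCC(C)C)c(F)c2)C(=O)O1` is not yet measured. It differs from compound 1 in one place (isopentyl in place of phenyl on an amine nitrogen). For the measured compounds named here, one measured step bears on this: a number 0.58 log units higher from compound 1 to compound 2 (beyond the scatter), made by the same replacement on the same amine nitrogen. A rise of similar size is therefore expected, a number 0.58 log units higher from compound 1 to compound 3 (beyond the scatter), so compound 3 is estimated at 1.17, in a range from 0.87 to 1.47.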

Compound 3, partition coefficient: 1.19
Compound 3: the middle estimate sits 0.02 log units below what was measured; the range from low to high includes it.
By their numbers in this assay, from the lowest: compound 1; then compounds 2 and 3 (each within the scatter of the next).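

With the configuration as drawn held constant, isopentyl in place of phenyl on the amine nitrogen gives, in this assay, a number 0.60 log units higher from compound 1 to compound 3 (beyond the scatter). Inverting the stereocentre at the saturated chain carbon gives a number 0.02 log units higher from compound 2 to compound 3 (within the scatter), so this stereocentre makes no readable difference with isopentyl in place. That pair isolates configuration, and nothing else: the fact that compounds 2 and 3 differ only in the configuration as drawn

Still open, going by these compounds, is how a cyclohexyl group or a longer chain on the same amine nitrogen would read. On these data alone, it is also open whether the stereocentre would matter as little with phenyl on that nitrogen.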